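A few compounds are considered here, and "the series" means these few. Any claim that something is new, unique, unknown or untested is made for them only; others in the source may bear on it.

In an assay on microsomes from liver for inhibition of acyl-CoA desaturase 1 (Rattus norvegicus) (a lower number here means a stronger inhibitor, a higher number a weaker inhibitor), the two compounds sharing one core, compound 1 `CC(C)c1nnc(-c2ccc(N3CCC(Oc4ccccc4C(F)(F)F)CC3)nn2)s1` and compound 2 `Oc1nnc(-c2ccc(N3CCC(Oc4ccccc4C(F)(F)F)CC3)nn2)s1`, give closely matched numbers: compound 1 gives 8.8 nM and compound 2 gives 6.1 nM. Going by the values given here, the single measured step between them, a 1.4-fold lower number from compound 1 to compound 2 (0.16 log units; within the scatter), is a small one. Compound 3 `c1cc(OC2CCN(c3ccc(-n4ccnc4)nn3)CC2)c2cc[nH]c2c1` rests on a different core, and in this assay compound 3 gives 162 nM, the highest of the three numbers; its nearest neighbour is compound 1, its furthest compound 2, and both gaps lie beyond the scatter.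

Compound 4 `Cc1ccccc1OC1CCN(c2ccc(-n3ccnc3)nn2)CC1` is compound 3 changed in one place: 2-methylphenyl in place of 1H-indol-4-yl on an oxygen on a saturated carbon. Among the compounds with values here, no measured step bears on this kind of change. Within the data shown here, the only step in hand, a 1.4-fold lower number from compound 1 to compound 2 (0.16 log units; within the scatter), swaps a group on an aromatic carbon within a core that compound 3 and compound 4 do not share, so it gives no guide to what an exchange at the oxygen on the saturated carbon will do. With nothing to point either way, compound 4 is expected to land close to compound 3, the step from compound 3 to compound 4 being estimated at a 1.1-fold lower number from compound 3 to compound 4 (0.03 log units; within the scatter), a change not beyond the scatter. Accordingly compound 4 is estimated at 150 nM in this assay, within a range of 40 nM to 600 nM.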

Compound 4, half-maximal inhibitory concentration: 39 nM
Compound 4: middle estimate off by 3.8-fold (0.59 log units), on the high side, outside the stated range (below it).
By their numbers in this assay, from the lowest: compounds 2 and 1 (each within the scatter of the next); then compound 4; then compound 3.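

In this assay the group on an oxygen on a saturated carbon proves able to move the number: with the rest of compound 3 unchanged, 2-methylphenyl in place of 1H-indol-4-yl gives a 4.2-fold lower number from compound 3 to compound 4 (0.62 log units; beyond the scatter) and so counts as a modest step, though one that clears the scatter. The 1H-indol-4-yl group, with its five-membered aromatic ring and its hydrogen-bond donor, is therefore not needed to reach this level on this core, since 2-methylphenyl, with one six-membered aromatic ring of carbon only and no hydrogen-bond donor, gives the lower number. No measurement here explains the step, and this single pair cannot separate the loss of the five-membered ring, the loss of the donor and the gain of the methyl.

As far as these compounds go, it remains open whether the methyl contributes at all, which an unsubstituted phenyl would test, and how a ring carrying an amine or a carboxylic acid would fare at this place. Also open, from the compounds shown here alone, is whether the same exchange would give a step of similar size on the core of compound 1.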